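From an Amino Link to an Oxygen Link in Compound 4

A few compounds are considered here, and "the series" means these few. Any claim that something is new, unique, unknown or untested is made for them only; others in the source may bear on it.

Of the compounds shown here, three built on one shared core have been tested in an ADME assay on BaF3 cells (Mus musculus) for antiproliferative activity, read by CellTiter-Glo and CCK-8 assay, with a stated time of 72 h; on this read-out lower numbers stand for stronger inhibition of growth and higher numbers for weaker inhibition of growth. Compound 1 `Cc1ccc(Nc2ncc3c(n2)N(C)C(=O)N(c2cc(NC(=O)c4cccc(C(F)(F)F)c4)ccc2C)C3)cc1C` gives 3760 nM. Compound 2 `CNc1cc(Nc2ncc3c(n2)N(C)C(=O)N(c2cc(NC(=O)c4cccc(C(F)(F)F)c4)ccc2C)C3)ccc1C` reaches only the limit of the assay, > 10000 nM, so no number is known for it. Compound 3 `Cc1ccc(Nc2ncc3c(n2)N(C)C(=O)N(c2cc(NC(=O)c4cccc(C(F)(F)F)c4)ccc2C)C3)cc1N` gives 440 nM, the lowest of the two actual numbers. Among the compounds with values here, the step of an 8.5-fold lower number from compound 1 to compound 3 (0.93 log units; beyond the scatter) is the only measured step between two numbers; the other two, an at least 2.6-fold higher number from compound 1 to compound 2 (0.42 log units; beyond the scatter) and an at least 22-fold lower number from compound 2 to compound 3 (1.35 log units; beyond the scatter), involve the limit and concern the same group as that step.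

Compound 4 `Cc1ccc(Oc2ncc3c(n2)N(C)C(=O)N(c2cc(NC(=O)c4cccc(C(F)(F)F)c4)ccc2C)C3)cc1N` has not yet been measured. It differs from compound 3 in one place: 3-amino-4-methylphenoxy in place of (3-amino-4-methylphenyl)amino on an aromatic carbon. None of the three measured steps touches this place, so they give no direct guide to how large the change will be or in which direction it will run, and the estimate is wide. For compound 4 the expected value in this assay is 2000 nM, within a range from 400 nM to 10000 nM. This estimate means an expected step of a 4.5-fold higher number from compound 3 to compound 4 (0.66 log units; beyond the scatter), a weakening that may or may not lie beyond the scatter.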

Compound 4, concentration for 50% growth inhibition: > 10000 nM
Compound 4: only a limit was reported; the forecaster's own chance of this, stated with the estimate: 25%; at least 5.0-fold (0.69 log units) between middle value and limit.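

In this assay compound 4 gives > 10000 nM, which is a limit of the assay and not a number. The earlier compounds shown here varied only the group on the phenyl ring, whereas here that ring keeps its amino group and only the link to the shared core changes, from nitrogen to oxygen; the result is an at least 22-fold higher number from compound 3 to compound 4 (1.35 log units; beyond the scatter), so at this position the amino group on the ring is not enough to keep the activity without the amino link. The same link change leaves an at least 2.6-fold higher number from compound 1 to compound 4 (0.42 log units; beyond the scatter), while the step that joins compound 2 and compound 4 cannot be read, because both of its values are limits: the limit of > 10000 nM in this assay, at which 2 of the 4 values shown sit.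

From the compounds shown here alone, how far beyond the limit compound 4 truly lies remains open. So does whether a sulfur atom or a methylene group as the link would keep the activity of compound 3.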